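The compounds below may be only part of what the source reports. "The series", "measured", "known", "first", "only" and "open" are said of these compounds alone.

Values in a functional assay on KYSE-70 cells for antiproliferative activity against KYSE-70 cell line (Homo sapiens), read by MTT assay, with a stated time of 72 h; on this read-out lower numbers stand for stronger inhibition and higher numbers for weaker inhibition:
- Compound 1 `CC(C)(C)c1ccc(-c2ccc3c(C(=O)Nc4cccc(F)c4)cc(=O)[nH]c3c2)cc1`: > 20000 nM
- Compound 2 `O=C(Nc1cccc(F)c1)c1cc(=O)[nH]c2cc(-c3ccsc3)ccc12`: 5100 nM

The value of compound 1 is a limit, not a number. For the measured compounds named here, compound 2 therefore holds the only true number in this assay, and it can be compared only with that limit. Going by the values given here, the single measured step is an at least 3.9-fold lower number from compound 1 to compound 2 (0.59 log units; beyond the scatter). Its size is only a minimum, given (the limit of > 20000 nM in this assay, at which 1 of the 2 values shown sits).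

Compound 3 `O=C(Nc1cccc(F)c1)c1cc(=O)[nH]c2cc(-c3cccc(F)c3)ccc12` keeps the shared core and changes the same aromatic carbon again, with 3-fluorophenyl in place of thiophen-3-yl on an aromatic carbon. This brings back a six-membered aromatic ring of carbon only, the ring type that compound 1 carries, though without its tert-butyl group. Among the compounds with values here, the step of an at least 3.9-fold lower number from compound 1 to compound 2 (0.59 log units; beyond the scatter) is the only evidence that bears on this change, and it suggests that part of the gain could be lost, but probably not all of it. The expected change is modest and toward weaker inhibition, estimated as a 2.0-fold higher number from compound 2 to compound 3 (0.29 log units; within the scatter). For compound 3 the expected value is 10000 nM, with an estimated range from 3500 nM to 25000 nM.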

Compound 3, half-maximal inhibitory concentration: 12000 nM
For compound 3 the middle estimate is 1.2-fold (0.08 log units) below the measured one, within the range that was stated.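

In this assay, for the compounds shown here, this aromatic carbon now has two true numbers, so a swap of its ring can be sized without relying on a limit for the first time. Replacing thiophen-3-yl with 3-fluorophenyl gives a 2.4-fold higher number from compound 2 to compound 3 (0.37 log units; beyond the scatter) and shows that the choice of ring still matters once the 4-(tert-butyl)phenyl group is gone, with the five-membered ring carrying 1 hetero atom giving the lower number of this pair. Comparing the two six-membered rings gives an at least 1.6-fold lower number from compound 1 to compound 3 (0.22 log units; that floor lies within the scatter), but this is only a minimum, so compound 3 cannot be firmly placed relative to compound 1: the limit of > 20000 nM in this assay, at which 1 of the 3 values shown sits.

On these data alone, compounds 2 and 3 differ in both ring size and atoms, so it remains open whether the sulfur, the fluorine or the ring itself accounts for the step, a question that plain phenyl or thiophen-2-yl at this carbon would help to separate. Also open, as far as these compounds go, is how this position would respond to a pyridine ring, or to a phenyl ring bearing an amine or a carboxylic acid.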